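The source may hold more compounds than are shown below. What is called first, only, known or untested is meant among the compounds shown, and "the series" means these compounds.

Measured compounds in this series:
compound 1 `Nc1nc(NC2CC2)c2ncn(/C=C3/CC3(CO)CO)c2n1` — 71500 nM
compound 2 `CCCCNc1nc(N)nc2c1ncn2/C=C1/CC1(CO)CO` — a limit of the assay, > 20000 nM
compound 3 `Nc1nc(N2CCCC2)c2ncn(/C=C3/CC3(CO)CO)c2n1` — a limit of the assay, > 20000 nM

In an ADME assay on BCBL1 cells (Homo sapiens) for cytotoxicity, with a stated time of 7 days (a lower number here means that less compound is tolerated, a higher number that more compound is tolerated), compound 1 gives 71500 nM. For compound 2 the result is only a limit of the assay, > 20000 nM. Compound 2 therefore stands at the limit of > 20000 nM in this assay, at which 2 of the 3 values shown sit, with no readable number of its own. Compound 4 `CNc1nc(N)nc2c1ncn2/C=C1/CC1(CO)CO` differs from compound 2 by hydrogen in place of propyl on a saturated chain carbon bound to a nitrogen on an aromatic ring. For the measured compounds named here, the steps that change the group on the same nitrogen on an aromatic ring, a step that the limit leaves unreadable from compound 1 to compound 2 and a step that the two limits leave unreadable from compound 2 to compound 3, are both unreadable, so no measured step gives a size for this change. The expected step is a step that the limit leaves unreadable from compound 2 to compound 4, with no direction beyond the scatter. Compound 4 is estimated at 40000 nM, within 15000 nM to 120000 nM, and most likely again a limit.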

Compound 4, half-maximal cytotoxic concentration: 67000 nM
Compound 4: middle estimate off by 1.7-fold (0.22 log units), on the low side; measured number inside the range.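

In this assay the group on this nitrogen gets its first readable step, with methyl in place of cyclopropyl: a 1.1-fold lower number from compound 1 to compound 4 (0.03 log units; within the scatter). Methyl and cyclopropyl on this nitrogen therefore cannot be told apart here. Compound 2 and compound 3 each remain a limit, so every step that involves them cannot be read: the limit of > 20000 nM in this assay, at which 2 of the 4 values shown sit.

Going by these compounds, whether butyl or pyrrolidin-1-yl changes the tolerated concentration in either direction remains open. So does the outcome for a longer chain, such as hexyl, or for a chain ending in a carboxylic acid on this nitrogen.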